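Swapping the Oxolane Attachment Point on Compound 1

This account rests on a few compounds, and the source may have more. Where it says the series, first, only, none or still open, it means among the compounds named here.

Compound 1, with the structure `Cc1cc(C)c(CN2CCc3c(Cl)cc([C@H](CO)[C@H]4CCOC4)c(Cl)c3C2=O)c(=O)[nH]1`, is the reference point here. In a functional assay on KARPAS-422 cells (Homo sapiens) for antiproliferative activity, read by resazurin assay, with a stated time of 72 h (on this read-out lower numbers stand for stronger inhibition and higher numbers for weaker inhibition), compound 1 gives 15 nM, the lowest number among the values recorded. A second compound from the same series, compound 2, with the structure `COC(C)c1cc(Cl)c2c(c1Cl)C(=O)N(Cc1c(C)cc(C)[nH]c1=O)CC2`, was measured more than once; in this assay compound 2 gives 696 nM; 282 nM (2 entries), and the spread between these repeats, (the several entries of compound 2 in this assay, 696 nM; 282 nM (2 entries)), shows how much a single value of this kind can wander.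

Compound 3, with the structure `Cc1cc(C)c(CN2CCc3c(Cl)cc([C@H](CO)[C@H]4CCCO4)c(Cl)c3C2=O)c(=O)[nH]1`, is not yet measured. It keeps every atom of compound 1 but joins them differently: oxolan-2-yl in place of oxolan-3-yl on a saturated chain carbon bound to an aromatic carbon and a saturated chain carbon. Within the data shown here, no measured pair shows what this kind of change does, so the expected effect in this assay rests only on the fact that the same atoms are kept. The step of a 2.0-fold higher number from compound 1 to compound 3 (0.30 log units; within the scatter) is expected to stay small, with no clear direction beyond the usual scatter. For compound 3 the estimated value in this assay is 30 nM, with a likely range from 8 nM to 120 nM.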

Compound 3, half-maximal inhibitory concentration in the KARPAS-422 assay: 63 nM
Estimate against measurement, compound 3: 2.1-fold (0.32 log units) below; the range from low to high includes it.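

In the KARPAS-422 assay, changing only how the ring is attached, oxolan-2-yl in place of oxolan-3-yl, gives a 4.2-fold higher number from compound 1 to compound 3 (0.62 log units; beyond the scatter), so at this position the way the atoms are joined matters and not just which atoms are present. In a physicochemical assay for lipophilicity, at pH 7.4 (on this read-out higher numbers stand for higher lipophilicity and lower numbers for lower lipophilicity), compound 1 gives 2 and compound 3 gives 2.1, two values within the usual scatter of each other, so this read-out does not separate the pair. The step is modest, and a single value of this kind can wander, as the repeats of compound 2 show: the several entries of compound 2 in the KARPAS-422 assay, 696 nM; 282 nM (2 entries)

The compounds shown do not explain why the attachment point changes the result. They also leave open whether an amine such as pyrrolidine or an open methoxy chain in place of the oxolane ring would keep the activity of compound 1.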